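The source may report more compounds than this note shows. Statements on the series, on what has been measured and on what is new or still open speak of the compounds shown alone.

Measured compounds:
compound 1 `COCc1nc(Nc2ccc(C(F)(F)F)cc2)c2ccc(-c3ncccc3C(F)(F)F)cc2n1` — 1.5 nM
compound 2 `O=C(O)COCc1nc(Nc2ccc(C(F)(F)F)cc2)c2ccc(-c3ncccc3C(F)(F)F)cc2n1` — 81 nM
compound 3 `CC(C)NCc1nc(Nc2ccc(C(F)(F)F)cc2)c2ccc(-c3ncccc3C(F)(F)F)cc2n1` — 35 nM

In a functional assay for antagonist activity at transient receptor potential cation channel subfamily V member 1 (Homo sapiens) (on this read-out higher numbers stand for weaker inhibition and lower numbers for stronger inhibition), compound 3 stands second highest of the three, close to compound 2 but far from compound 1. Compound 4 `FC(F)(F)c1ccc(Nc2nc(CN3CCN(C4CCCC4)CC3)nc3cc(-c4ncccc4C(F)(F)F)ccc23)cc1` differs from compound 3 by 4-cyclopentylpiperazin-1-yl in place of isopropylamino on a saturated chain carbon bound to an aromatic carbon. Within the data shown here, the steps that bear on this position are a 23-fold higher number from compound 1 to compound 3 (1.37 log units; beyond the scatter) and a 2.3-fold lower number from compound 2 to compound 3 (0.36 log units; beyond the scatter): a basic amine at the saturated chain carbon bound to the aromatic carbon gave a large loss against the methoxy of compound 1, and a modest gain against the carboxymethoxy of compound 2. Among the measured compounds shown here, no measured step covers a tertiary amine or a ring at this position, so the expectation rests on compound 3 alone; a change within or modestly beyond the scatter is expected, direction uncertain, a 1.4-fold higher number from compound 3 to compound 4 (0.15 log units; within the scatter). Compound 4 is therefore estimated at 50 nM, between 10 nM and 250 nM.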

Compound 4, half-maximal inhibitory concentration: 8 nM
Beside the measured number, compound 4's estimate is 6.3-fold (0.80 log units) above it; the measured number lies below the stated range.
By their numbers in this assay, from the lowest: compound 1; then compound 4; then compound 3; then compound 2.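

In this assay the amine at this saturated chain carbon is not tied to the number of compound 3: the larger 4-cyclopentylpiperazin-1-yl gives a 4.4-fold lower number from compound 3 to compound 4 (0.64 log units; beyond the scatter) and recovers part of the loss seen there. The same group gives a 10-fold lower number from compound 2 to compound 4 (1.01 log units; beyond the scatter) against the carboxymethoxy, but still a 5.3-fold higher number from compound 1 to compound 4 (0.73 log units; beyond the scatter) against the methoxy, which keeps compound 1 lowest of the four. No measurement on hand accounts for these differences.

From the compounds shown here alone, whether the gain needs the cyclopentyl ring or the piperazine alone remains open, as a plain piperazine or a morpholine would show. Also open, going by these compounds, is whether an ethoxy holds the number of compound 1.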